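A few compounds are considered here, and "the series" means these few. Any claim that something is new, unique, unknown or untested is made for them only; others in the source may bear on it.

Compound 1 `COc1ccc(/C=C/C(=O)c2ccc(NC(=O)COc3ccc(/C(C)=N\O)cc3)cc2)cc1` and compound 2 `C/C(=N/O)c1ccc(OCC(=O)Nc2ccc(C(=O)/C=C/c3ccco3)cc2)cc1` share a core; in a functional assay on the whole organism (strain albino) for inhibition, with Rattus norvegicus as the target, read by paw edema, with stated times of 30 min and 1 h, at a dose of 100 mg/kg by the oral route (a higher number here means more inhibition at the dose given (going by the name of the read-out), a lower number less inhibition), compound 1 gives 33%, and compound 2 gives 36%. The change between them is furan-2-yl in place of 4-methoxyphenyl on a double-bonded chain carbon bound to a double-bonded chain carbon and the step it made is a number 3 percentage points higher from compound 1 to compound 2 (within the scatter). Compound 3 `COc1ccc(/C=C/C(=O)c2ccc(NC(=O)COCc3c(-c4ccccc4)no[n+]3[O-])cc2)cc1` has a different core; how it differs from compound 1 is not broken down here. In this assay compound 3 gives 30%. Compound 4 `O=C(COCc1c(-c2ccccc2)no[n+]1[O-])Nc1ccc(C(=O)/C=C/c2ccco2)cc1` is derived from compound 3 by the same change, (furan-2-yl in place of 4-methoxyphenyl on a double-bonded chain carbon bound to a double-bonded chain carbon). Because the earlier step of a number 3 percentage points higher from compound 1 to compound 2 (within the scatter) stayed within the scatter, the step to compound 4 is expected to be of similar size, a number 3 percentage points higher from compound 3 to compound 4 (within the scatter). Compound 4 is therefore estimated to give 33% in this assay, expected between 23% and 43%.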

Compound 4, a percentage reported as inhibition, in the whole organism at one dose (the size of the read-out at that dose, not a potency): 30%
For compound 4 the middle estimate is 3 percentage points above the measured one; measured number inside the range.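

Carried to a second core, furan-2-yl in place of 4-methoxyphenyl gave no change at the digits printed from compound 3 to compound 4 (within the scatter) in this assay. The change therefore behaved alike on both cores, as far as this read-out can tell: the same change on two cores in this assay, a number 3 percentage points higher (within the scatter) from compound 1 to compound 2 and no change at the digits printed (within the scatter) from compound 3 to compound 4, 3 percentage points apart, within the scatter of two such steps

This supports carrying the change between these two cores as a small step, but it rests on one pair per core at a single dose, and it does not show that the two groups are equivalent, as a real difference smaller than the scatter would go unseen.

The compounds shown leave open whether another group at this place, such as thiophen-2-yl or a pyridine ring, would move the number on either core. They also leave open whether a 4-aminophenyl group would.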